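A few compounds are considered here, and "the series" means these few. Any claim that something is new, unique, unknown or untested is made for them only; others in the source may bear on it.

Compound 1, `C[S+](=N)([O-])C[C@@](O)(CC(=O)O)C(=O)O`, is a sulfoximine analogue of the natural substrate; in an assay on isolated protein for inhibition of ATP-citrate synthase (Rattus norvegicus) (a higher number here means a weaker inhibitor, a lower number a stronger inhibitor), compound 1 gives > 10000000 nM; 250000 nM (2 entries), as the several entries of compound 1 in this assay, > 10000000 nM; 250000 nM (2 entries) records. Compound 2, `O=C(O)C[C@H](C[C@]1(O)CNC1=O)C(=O)O`, carries a hydroxylated lactam ring in place of that group. In this assay compound 2 gives > 9000000 nM, a limit of the assay and not a number, so compound 2 stands at the edge of what the assay can resolve, as the limit of > 9000000 nM in this assay, at which 1 of the 2 values shown sits, shows. Compound 3, `O=C(O)C[C@H](C[C@@]1(O)CNC1=O)C(=O)O`, is its ring epimer: the two compounds have the same atoms and bonds and differ only in configuration as drawn: 1 of 2 stereo elements differ; a stereocentre at a saturated ring carbon is drawn S in compound 2 and R in compound 3. Going by the values given here, no measured step between two compounds is available, and a change of configuration alone gives no direction to expect here; the step from compound 2 to compound 3 is therefore estimated as a number no higher from compound 2 to compound 3 (the limit leaves the size open), within the scatter. For compound 3 an inhibition constant near 9000000 nM is expected, somewhere between 1000000 nM and 50000000 nM, most probably again reported only as a limit.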

Compound 3, inhibition constant: > 20000000 nM
Compound 3 was reported as a limit; the forecaster's own chance of this, stated with the estimate: 80%; at least 2.2-fold (0.34 log units) between middle value and limit.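

In this assay, going by these compounds alone, compound 2 and compound 3 are both reported only as limits, so no step between them can be read. The compounds shown leave open how strongly either epimer inhibits the enzyme, and whether the configuration at that saturated ring carbon matters for inhibition.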